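Shortening the Side Chain of a Weakly Cytotoxic Purine Analogue

This account rests on a few compounds, and the source may have more. Where it says the series, first, only, none or still open, it means among the compounds named here.

Compound 3 `CCCCCCCCSc1nc(N)nc2c1ncn2/C=C1/CC1(CO)CO` is the only one of the three measured analogues that gives a number in an ADME assay on CCRF-HSB-2 cells (Homo sapiens) for cytotoxicity, with a stated time of 7 days; a higher number here means that more compound is tolerated, a lower number that less compound is tolerated: compound 3 gives 60000 nM. Compound 1 `CCCCNc1nc(N)nc2c1ncn2/C=C1/CC1(CO)CO` reaches only the limit of this assay, > 20000 nM. Compound 2 `Nc1nc2c(ncn2/C=C2/CC2(CO)CO)c(=O)[nH]1` likewise sits at the limit, > 20000 nM. Within the data shown here, the single step that links measured compounds, a step that the limit leaves unreadable from compound 1 to compound 3, cannot be read because of the limit of > 20000 nM in this assay, at which 2 of the 3 values shown sit. Compound 4 `CNc1nc(N)nc2c1ncn2/C=C1/CC1(CO)CO` carries methylamino in place of octylsulfanyl on an aromatic carbon. Among the measured compounds shown here, no measured step bears readably on this change, and the nearest neighbour, compound 1, stands at a limit. The step of a 1.5-fold lower number from compound 3 to compound 4 (0.18 log units; within the scatter) is therefore expected to be small. In this assay compound 4 is estimated at 40000 nM, with a range from 20000 nM to 100000 nM.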

Compound 4, half-maximal cytotoxic concentration: > 20000 nM
Compound 4 was reported as a limit (the forecaster's own chance of this, stated with the estimate: 70%); the middle value does not contradict the limit.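

Neither the step from compound 3 to compound 4 nor the step from compound 1 to compound 4 can be read, because both run into a limit: the limit of > 20000 nM in this assay, at which 3 of the 4 values shown sit.

From the compounds shown here alone, how the tolerated concentrations of compound 1, compound 2 and compound 4 compare with that of compound 3 stays open.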